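The source may report more compounds than this note shows. Statements on the series, on what has been measured and on what is new or still open speak of the compounds shown alone.

In a functional assay on MCF7 cells (Homo sapiens) for cytotoxicity, read by MTT assay, with a stated time of 72 h (a higher number here means a weaker inhibitor, a lower number a stronger inhibitor), compound 1 (`CSc1nc(Br)c(C(=O)c2ccccc2)s1`) gives 67000 nM, compound 2 (`CCOC(=O)c1sc(N2CCCC2)nc1Cl`) gives 79000 nM and compound 3 (`O=C(c1ccccc1)c1sc(N2CCCC2)nc1Cl`) gives 63000 nM. These three numbers all lie within the usual scatter of one another, so compound 3 stands level with the other two, and none of them can be ranked.

The next compound, compound 4 (`O=C(c1ccccc1)c1sc(N2CCCC2)nc1Br`), is made from compound 3 by a single change: bromo in place of chloro on an aromatic carbon. In words, bromo replaces chloro on an aromatic carbon, next to the ring nitrogen.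

Among the measured compounds shown here, no measured pair shows this exact swap, so the evidence is indirect. For the measured compounds named here, the one measured single-place step, phenyl in place of ethoxy on a carbonyl carbon, is a 1.3-fold lower number from compound 2 to compound 3 (0.10 log units; within the scatter), and it stays within the scatter. Going by the values given here, compound 1 is the only measured compound that already bears a bromo, although it also differs from compound 3 elsewhere, and compound 1 gives 67000 nM, a number within the scatter of the other two.

Nothing here points to a real shift in this assay, in either direction. The estimated step is a 1.1-fold lower number from compound 3 to compound 4 (0.02 log units; within the scatter), which is expected to stay within the scatter. For compound 4 the expected value is 60000 nM, with an estimated range from 32000 nM to 100000 nM.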

Compound 4, half-maximal inhibitory concentration: 69000 nM
Compound 4: the middle estimate sits 1.2-fold (0.06 log units) below what was measured; low and high end bracket the measured number.
By their numbers in this assay, from the lowest: compounds 3, 1, 4 and 2 (each within the scatter of the next).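

In this assay, the change from chloro to bromo on the aromatic carbon next to the ring nitrogen now has a direct measured pair: a 1.1-fold higher number from compound 3 to compound 4 (0.04 log units; within the scatter). Among the compounds shown here, at this position, then, the two halogens cannot be told apart in this cell test, which the earlier compounds could only suggest indirectly. The second pair adds a different place, the ring atom that bears the pyrrolidin-1-yl group, where that group stands in for methylsulfanyl, and it reads a 1.0-fold higher number from compound 1 to compound 4 (0.01 log units; within the scatter), so this swap cannot separate the two compounds either. No measurement on hand offers an explanation for these readings.

What the compounds shown leave open is whether anything other than a halogen at this position, such as an amine or a nitrile, would move the number beyond the scatter. On these data alone, it is equally open whether a different group in place of the pyrrolidin-1-yl group, such as a piperazine or a longer chain ending in a carboxylic acid, would separate itself from the four compounds that so far cannot be ranked.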